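The source may report more compounds than this note shows. Statements on the series, on what has been measured and on what is new or still open speak of the compounds shown alone.

For the measured compounds named here, compound 1 `Nc1nc(N)c2cc(CSC(=S)N3CCN(c4ccccc4)CC3)ccc2n1` and compound 2 `Nc1nc(N)c2cc(CSC(=S)N3CCN(c4ccc(Cl)cc4)CC3)ccc2n1` are the two measured members. In a functional assay on HeLa cells (Homo sapiens) for antiproliferative activity, read by MTT assay, with a stated time of 72 h (a lower number here means a stronger inhibitor, a higher number a weaker inhibitor), compound 1 gives 2840 nM, and compound 2 gives 6990 nM, the highest of the two numbers. Going by the values given here, the single measured step is a 2.5-fold higher number from compound 1 to compound 2 (0.39 log units; beyond the scatter). Compound 3 `Nc1nc(N)c2cc(CSC(=S)N3CCN(c4ncccn4)CC3)ccc2n1` differs from compound 2 by pyrimidin-2-yl in place of 4-chlorophenyl on an amine nitrogen in a ring. Among the compounds with values here, no measured step covers this exchange directly; a 2.5-fold higher number from compound 1 to compound 2 (0.39 log units; beyond the scatter) bears on it only in that the chloro leaves again, and that step was modest. Within the data shown here, the six-membered aromatic ring with 2 hetero atoms that enters has no counterpart among the measured compounds, so its own effect is unknown. For compound 3 the expected step is a 2.0-fold lower number from compound 2 to compound 3 (0.30 log units; within the scatter), a return toward the lower number of compound 1 rather than anything larger. The estimate for compound 3 in this assay is 3500 nM, with a range of 1200 nM to 10000 nM.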

Compound 3, half-maximal inhibitory concentration: 4360 nM
The estimate for compound 3 lay 1.2-fold (0.10 log units) below the measured number; the measured number falls inside the stated range.
By their numbers in this assay, from the lowest: compounds 1, 3 and 2 (each within the scatter of the next, the first and the last beyond it).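

In this assay the place on the amine nitrogen in a ring accepts pyrimidin-2-yl, a six-membered aromatic ring with 2 hetero atoms, without a step beyond the scatter from either carbon-only ring: a 1.5-fold higher number from compound 1 to compound 3 (0.19 log units; within the scatter) and a 1.6-fold lower number from compound 2 to compound 3 (0.20 log units; within the scatter). Compound 3 therefore cannot be separated from compound 1 or compound 2, although those two remain apart by a 2.5-fold higher number from compound 1 to compound 2 (0.39 log units; beyond the scatter), so among these three compounds only the step that adds chloro lies beyond the scatter. Nothing at hand bears on why the numbers fall as they do.

Open, as far as these compounds go, is whether a non-aromatic group at the same place, such as cyclohexyl or a simple methyl, would give a step beyond the scatter from compound 1. Also open, from the compounds shown here alone, is whether the step with chloro is particular to that atom, which fluoro or methoxy on the phenyl ring could test.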